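A few compounds are considered here, and "the series" means these few. Any claim that something is new, unique, unknown or untested is made for them only; others in the source may bear on it.

Measured in a functional assay on WM 266-4 cells (Homo sapiens) for antiproliferative activity, read by MTT assay, with a stated time of 24 h; on this read-out lower numbers stand for stronger inhibition of growth and higher numbers for weaker inhibition of growth:
- Compound 1 `c1ccc(N2N=C(c3ccc4c(c3)OCCO4)CC2c2ccco2)cc1`: > 100000 nM, a limit of the assay and not a number
- Compound 2 `Fc1ccc(C2CC(c3ccc4c(c3)OCCO4)=NN2c2ccccc2)cc1`: 6050 nM
- Compound 3 `Cc1ccc(C2CC(c3ccc4c(c3)OCCO4)=NN2c2ccccc2)cc1`: 2530 nM

Compound 3 has the lowest number in this assay, and its nearest neighbour is compound 2 at 6050 nM. Compound 4 `COc1ccc(C2CC(c3ccc4c(c3)OCCO4)=NN2c2ccccc2)cc1` differs from compound 3 in one place, with methoxy in place of methyl on an aromatic carbon, para to a large group (methoxy in place of methyl on an aromatic carbon).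

For the measured compounds named here, the only measured change on that aromatic carbon is a 2.4-fold lower number from compound 2 to compound 3 (0.38 log units; beyond the scatter), which is modest. The far larger steps an at least 16-fold lower number from compound 1 to compound 2 (1.21 log units; beyond the scatter) and an at least 39-fold lower number from compound 1 to compound 3 (1.59 log units; beyond the scatter) replace furan-2-yl on a saturated ring carbon, so they say little about this change. On the evidence of a 2.4-fold lower number from compound 2 to compound 3 (0.38 log units; beyond the scatter), a modest step at most is expected in this assay, with no firm direction and a slightly higher number marginally favoured. The expected change is a 1.2-fold higher number from compound 3 to compound 4 (0.07 log units; within the scatter). For compound 4 the estimated value is 3000 nM, with an expected range from 1000 nM to 9000 nM.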

Compound 4, concentration for 50% growth inhibition: > 100000 nM
Compound 4 was reported as a limit; the forecaster's own chance of this, stated with the estimate: 3%; middle value at least 33-fold (1.52 log units) from the limit.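

In this assay, for the compounds shown here, the one earlier change on this aromatic carbon was modest, so the position looked tolerant, but methoxy in place of methyl gives an at least 39-fold higher number from compound 3 to compound 4 (1.59 log units; beyond the scatter), and methoxy in place of fluoro gives an at least 16-fold higher number from compound 2 to compound 4 (1.21 log units; beyond the scatter). The outcome at this carbon therefore depends sharply on which group sits there, and a change this small in the 4-methylphenyl to 4-methoxyphenyl swap can matter as much as the furan-2-yl change did, although the step between compound 1 and compound 4 cannot be read. The value of compound 4 is a limit and not a number: the limit of > 100000 nM in this assay, at which 2 of the 4 values shown sit.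

With only fluoro, methyl and methoxy shown on this carbon, it remains open whether a hydroxyl, an amine or an ethoxy group would keep the growth inhibition seen with compound 3. From the compounds shown here alone, it also remains open whether the oxygen of methoxy is what matters, a question that an ethyl group here could address.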